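This account rests on a few compounds, and the source may have more. Where it says the series, first, only, none or still open, it means among the compounds named here.

The compounds here share a common core and differ only in the small groups hung on its outer rings. Compound 1 `COc1cccc2occ(Cc3coc4ccccc4c3=O)c(=O)c12` carries a single methoxy group. Compound 2 `O=c1c(Cc2coc3cccc(OCC4CCCCC4)c3c2=O)coc2cc(O)ccc12` carries a cyclohexylmethoxy group on one side and a free hydroxyl on the other, while compound 3 `COc1ccc2c(=O)c(Cc3coc4cccc(OCC5CCCCC5)c4c3=O)coc2c1` keeps the cyclohexylmethoxy group and has a methoxy where compound 2 has the hydroxyl.

In a functional assay on ACHN cells (Homo sapiens) for antiproliferative activity, read by XTT assay (on this read-out higher numbers stand for weaker inhibition and lower numbers for stronger inhibition), compound 1 gives 340 nM, compound 2 gives 2100 nM and compound 3 gives 1350 nM. Compound 1 thus has the lowest number of the three, with compound 3 nearest and compound 2 furthest, both gaps beyond the scatter. Between the other two, a 1.6-fold lower number from compound 2 to compound 3 (0.19 log units; within the scatter).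

Compound 4 `O=c1c(Cc2coc3ccccc3c2=O)coc2ccccc12` is compound 1 with its only substituent removed: hydrogen in place of methoxy on an aromatic carbon. The methoxy leaves and a hydrogen enters on an aromatic carbon of a six-membered aromatic ring of carbon only, part of a fused system of two rings. Among the measured compounds shown here, no measured pair shows this change. For the measured compounds named here, the one measured step, from compound 2 to compound 3, alters what sits on an oxygen rather than removing the oxygen, and stays within the scatter, so it offers little guidance. The expected step is therefore modest, a 1.8-fold higher number from compound 1 to compound 4 (0.25 log units; within the scatter), with real uncertainty in either direction. Compound 4 is estimated at 600 nM, within a range from 200 nM to 2000 nM.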

Compound 4, half-maximal inhibitory concentration: 510 nM
Beside the measured number, compound 4's estimate is 1.2-fold (0.07 log units) above it; the range from low to high includes it.
By their numbers in this assay, from the lowest: compounds 1 and 4 (each within the scatter of the next); then compounds 3 and 2 (each within the scatter of the next).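

Taking the methoxy group off this aromatic carbon of a six-membered aromatic ring of carbon only gives a 1.5-fold higher number from compound 1 to compound 4 (0.18 log units; within the scatter) in this assay, the first direct reading of a change at this position. The earlier step concerned only what sits on an oxygen, whereas this one removes the oxygen along with its methyl, and the result shows that the core carrying no substituent at all, compound 4, stays within the scatter of compound 1, so on this read-out the methoxy group is not needed to keep the activity seen with compound 1. No independent measurement is available here to explain why this exchange of methoxy for hydrogen leaves the number so little changed.

Going by these compounds, what this carbon does with a different kind of group, such as an amine, a carboxylic acid or a longer chain of carbon atoms, remains open. Also open, on these data alone, is whether hydrogen and methoxy would remain this close on a compound that carries the cyclohexylmethoxy group, since this single pair speaks only for the core without it.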